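The source may report more compounds than this note shows. Statements on the series, on what has been measured and on what is new or still open speak of the compounds shown alone.

Working notes on the series. Three amide compounds have been measured in a functional assay on A549 cells (Homo sapiens) for cytotoxicity, read by MTT assay, with a stated time of 72 h; a higher number here means a weaker inhibitor, a lower number a stronger inhibitor. Compound 1 `O=C(CN1CCN(c2nnc(Cc3ccncc3)c3ccccc23)CC1)Nc1ccc(F)c(F)c1` gives 3790 nM, the lowest number among the two reported. Compound 3 `O=C(CN1CCN(c2nnc(Cc3ccccc3)c3ccccc23)CC1)Nc1c(F)cccc1F` gives 84500 nM, a much higher number, beyond the scatter. Compound 2 `O=C(CN1CCN(c2nnc(Cc3ccccc3)c3ccccc23)CC1)Nc1cccc(Br)c1` is reported as "not active" (no number reported), with no number given. Among the measured compounds shown here, compounds 2 and 3 differ from compound 1 in more than one place, so no single step between measured compounds can be read from them.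

Compound 4 `Cc1ccc(F)cc1NC(=O)CN1CCN(c2nnc(Cc3ccncc3)c3ccccc23)CC1` is the next candidate. Relative to compound 1 the change is 5-fluoro-2-methylphenyl in place of 3,4-difluorophenyl on an amide-type nitrogen. The two compounds that carry a substituted ring on the amide nitrogen other than the 3,4-difluorophenyl of compound 1 gave a weak or absent response, so a shift toward a higher number is expected, though the support is thin. The expected step of a 4.0-fold higher number from compound 1 to compound 4 (0.60 log units; beyond the scatter) is taken to lie beyond the scatter, toward weaker inhibition. Compound 4 is estimated at 15000 nM, with a likely range from 4000 nM to 60000 nM.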

Compound 4, half-maximal inhibitory concentration: 38900 nM
Compound 4: middle estimate off by 2.6-fold (0.41 log units), on the low side, and the stated range covers the measured number.
By their numbers in this assay, from the lowest: compound 1; then compound 4; then compound 3.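

Replacing 3,4-difluorophenyl with 5-fluoro-2-methylphenyl on an amide-type nitrogen, with the rest of the molecule unchanged, gives a 10-fold higher number from compound 1 to compound 4 (1.01 log units; beyond the scatter) in this assay. Among the compounds shown here, this is the first single-place comparison, and it shows that the number in this assay responds strongly to the aryl group at this position; the steps to compounds 2 and 3 cannot be read, as each differs from compound 1 in more than one place. No available measurement accounts for the size of this step.

The two substituent patterns differ in more than one respect, and the compounds shown do not separate the contribution of the added methyl group from that of the changed fluorine pattern. Also open, from the compounds shown here alone, is whether a methoxy group or an amine on this phenyl ring would give a lower number than compound 1 does.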